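Swapping the pyrrolidine arm on a shared core

A few compounds are considered here, and "the series" means these few. Any claim that something is new, unique, unknown or untested is made for them only; others in the source may bear on it.

Measured compounds:
compound 1, `Nc1ncnc2c1c(-c1ccc(Oc3ccccc3)cc1)cn2C[C@H]1CCCN1C(CO)CO`, 15300 nM
compound 2, `CC(C)(C)c1ccc(C(=O)Nc2cccc(-c3cn([C@H]4CCN(C[C@@H]5CO5)C4)c4ncnc(N)c34)c2)cc1`, 4820 nM

The account follows two measured compounds and one that is still to be tested. In a functional assay on Ramos cells (Homo sapiens) for antiproliferative activity (on this read-out lower numbers stand for stronger inhibition and higher numbers for weaker inhibition), compound 1 gives 15300 nM, the higher of the two numbers, while compound 2 gives 4820 nM in this assay; the gap between them lies beyond the usual scatter, so compound 2 inhibits more strongly. Among the measured compounds shown here, these two compounds differ in more than one place, so no single step between them can be isolated.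

Compound 3, `Nc1ncnc2c1c(-c1ccc(Oc3ccccc3)cc1)cn2[C@H]1CCN(C[C@@H]2CO2)C1`, keeps the core and the phenoxyphenyl group of compound 1 and changes the substituent on the aromatic nitrogen: 1-((oxiran-2-yl)methyl)pyrrolidin-3-yl in place of (1-(2-hydroxy-1-(hydroxymethyl)ethyl)pyrrolidin-2-yl)methyl on an aromatic nitrogen. The group that enters is the same one that compound 2 carries on that nitrogen. For the measured compounds named here, no measured pair isolates this change, so the direction and size of the step rest on this resemblance alone. A moderate move toward stronger inhibition is expected, a 2.6-fold lower number from compound 1 to compound 3 (0.41 log units; beyond the scatter), since compound 2 with the same arm gives 4820 nM. Compound 3 is therefore estimated at 6000 nM, with a range from 1500 nM to 20000 nM.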

Compound 3, half-maximal inhibitory concentration: 6710 nM
Compound 3: middle estimate off by 1.1-fold (0.05 log units), on the low side, and the stated range covers the measured number.
By their numbers in this assay, from the lowest: compounds 2 and 3 (each within the scatter of the next); then compound 1.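

In this assay, among the compounds shown here, the change on the aromatic nitrogen gives the first comparison in this set that isolates one place: a 2.3-fold lower number from compound 1 to compound 3 (0.36 log units; beyond the scatter) with the core and the phenoxyphenyl group held fixed. The position therefore responds to 1-((oxiran-2-yl)methyl)pyrrolidin-3-yl in place of (1-(2-hydroxy-1-(hydroxymethyl)ethyl)pyrrolidin-2-yl)methyl, although the step is modest. Nothing available here accounts for the size or direction of this step.

The three-membered ring, the loss of the two hydroxyl-bearing arms and the shift of the attachment from pyrrolidin-2-yl methyl to pyrrolidin-3-yl all arrive together, and the compounds shown leave open which of these carries the step. Also open, going by these compounds, is how an acryloyl group or a plain 2-hydroxyethyl chain in place of the (oxiran-2-yl)methyl group would read in this assay on this same core.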